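Replacing Methyl with Chlorine on the Benzyl Group

The compounds below may be only part of what the source reports. "The series", "measured", "known", "first", "only" and "open" are said of these compounds alone.

Of the compounds shown here, three built on one shared core have so far been tested in a functional assay on HeLa cells (Homo sapiens) for cytotoxicity, read by cell counting, with a stated time of 4 days; a lower number here means a stronger inhibitor, a higher number a weaker inhibitor. Compound 2 `C=C(Br)C(=O)Nc1cccc(/C=C2\SC(=O)N(Cc3ccc(C)cc3)C2=O)c1` gives 1200 nM. Compound 1 `C=C(Br)C(=O)Nc1cccc(/C=C2\SC(=O)N(Cc3ccc(Cl)cc3)C2=O)c1` gives 2700 nM, and compound 3 `C=C(Br)C(=O)Nc1ccc(/C=C2\SC(=O)N(Cc3cccc(F)c3)C2=O)cc1` gives 5900 nM. Compound 2 thus has the lowest number of the three, its nearest neighbour being compound 1 and its furthest compound 3. For the measured compounds named here, the only single-point step among them is a 2.3-fold lower number from compound 1 to compound 2 (0.35 log units; beyond the scatter), the change of methyl in place of chloro on an aromatic carbon. Compound 3 differs from compound 2 in two places at once, so its value shows only that it sits higher.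

Compound 4 `C=C(Br)C(=O)Nc1cccc(/C=C2\SC(=O)N(Cc3cccc(Cl)c3)C2=O)c1` is still unmeasured. Compared with compound 2 the change is 3-chlorophenyl in place of 4-methylphenyl on a saturated chain carbon bound to an amide-type nitrogen in a ring. Going by the values given here, the one step that speaks to this is a 2.3-fold lower number from compound 1 to compound 2 (0.35 log units; beyond the scatter), which went in the opposite direction when methyl replaced chloro; compound 4 brings chlorine back, now as 3-chlorophenyl rather than the 4-chlorophenyl of compound 1. A modest move toward a higher number is therefore expected, of about a 2.1-fold higher number from compound 2 to compound 4 (0.32 log units; beyond the scatter). Compound 4 is estimated to give 2500 nM, with a likely range from 900 nM to 7000 nM.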

Compound 4, half-maximal inhibitory concentration: 2500 nM
The estimate for compound 4 equals the measured number at the digits printed; the range from low to high includes it.
By their numbers in this assay, from the lowest: compound 2; then compounds 4 and 1 (each within the scatter of the next); then compound 3.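

At this position, on a saturated chain carbon bound to an amide-type nitrogen in a ring, the new result shows that the earlier chlorine effect is not confined to 4-chlorophenyl: in this assay, there is a 2.1-fold higher number from compound 2 to compound 4 (0.32 log units; beyond the scatter) when 3-chlorophenyl replaces 4-methylphenyl. The exchange of 4-chlorophenyl for 3-chlorophenyl gives a 1.1-fold lower number from compound 1 to compound 4 (0.03 log units; within the scatter), so these two chlorinated groups cannot be told apart in this assay, and both compounds stand apart from compound 2, which carries 4-methylphenyl. No measurement at hand explains why the methyl and chloro compounds differ or why the two chlorinated compounds match.

Since 3-methylphenyl is absent from the compounds shown, the effect of placing a methyl group there remains open, as does the question of whether compound 2 owes its lower number to the methyl group itself or to its location on the ring. From the compounds shown here alone, it is also open how this position would respond to a plain phenyl group with no substituent, or to a ring bearing a methoxy group, an amine or a carboxylic acid.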